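The source may hold more compounds than are shown below. What is called first, only, known or untested is meant among the compounds shown, and "the series" means these compounds.

In an ADME assay on HepG2 cells (Homo sapiens) for cytotoxicity, read by CellTiter-Glo, with a stated time of 72 h (a higher number here means that more compound is needed for the effect, a lower number that less compound is needed), the measured compounds are these.

compound 1 `C[C@@H]1CC[C@H]2CC3C(=O)CC[C@@]31C2(C)C` gives 26000 nM
compound 2 `C/C1=C/C2=C[C@H](C)C[C@@]23O[C@]2(CC(C)(C)C[C@@H]2[C@@]1(O)C(F)(F)F)[C@@H](C)C3=O` gives 26000 nM

Compound 2 stands level with compound 1, and the two values lie within the usual scatter of each other. Compound 3 `C/C1=C/C2=C[C@H](C)C[C@@]23O[C@]2(CC(C)(C)C[C@@H]2[C@@]1(O)C#N)[C@@H](C)C3=O` departs from compound 2 in one place, with cyano in place of trifluoromethyl on a saturated ring carbon of the shared core. Among the measured compounds shown here, no measured pair here shows what this exchange does on its own. The expectation therefore rests only on compound 2 at 26000 nM and on compound 1 at 26000 nM, two different structures that read alike. In this assay no change beyond the scatter is expected, and the estimated step of a 1.0-fold lower number from compound 2 to compound 3 (0.02 log units; within the scatter) stays within it. For compound 3 the expected value is 25000 nM, with an estimated range of 10000 nM to 55000 nM.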

Compound 3, half-maximal effective concentration: 26000 nM
For compound 3 the middle estimate is 1.0-fold (0.02 log units) below the measured one, within the range that was stated.
By their numbers in this assay, from the lowest: compounds 1, 2 and 3 (each within the scatter of the next).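

Among the compounds shown here, the exchange of trifluoromethyl for cyano on a saturated ring carbon gives no change at the digits printed from compound 2 to compound 3 (within the scatter) in this assay and so supplies the first measured pair for this position. At this place, next to the ring atom that bears a fused ring, the two groups read alike despite their different heavy-atom counts, though this rests on one pair only. No measurement at hand offers an explanation for this result.

Going by these compounds, whether other groups would also read alike here stays open: an amine, a carboxylic acid or a longer chain at the same place could read alike or apart in this assay and this pair gives no guide to which. On these data alone, it is also open whether the same exchange would read alike on a different core, such as that of compound 1.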